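Extending the branch on compound 1 toward a hydroxypropyl chain

The source may hold more compounds than are shown below. What is called first, only, known or untested is meant among the compounds shown, and "the series" means these compounds.

Measured compounds:
- compound 1, `CCCCc1cnc(C(C)Cc2ccc(-c3ccccc3C(=O)O)cc2)[nH]1`: 184 nM
- compound 2, `CC(C)(C)c1cnc(CCc2ccc(-c3ccccc3C(=O)O)cc2)[nH]1`: 2750 nM

In an in vitro functional assay on cells for agonist activity at Bombesin receptor subtype-3 (Mus musculus), read by luminescence and calcium flux (a higher number here means that more compound is needed for the effect, a lower number that less compound is needed), compound 1 gives 184 nM, the lowest of the two numbers. Compound 2, in this assay, gives 2750 nM, a gap that lies beyond the scatter; the two compounds differ in more than one place, so no single step can be read from that pair.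

Compound 3, `CCCCc1cnc(C(CCCO)Cc2ccc(-c3ccccc3C(=O)O)cc2)[nH]1`, has not yet been measured in this assay. It differs from compound 1 by 2-hydroxyethyl in place of hydrogen on a saturated chain carbon, two bonds along the chain from an aromatic carbon. Among the compounds with values here, no measured pair shows this change, so its effect is unknown. The author expects a step of modest size from compound 1 to compound 3, probably toward a somewhat higher number, and possibly none beyond the scatter, estimated as a 1.7-fold higher number from compound 1 to compound 3 (0.24 log units; within the scatter). For compound 3 the estimated value in this assay is 320 nM, with a range from 80 nM to 1300 nM.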

Compound 3, half-maximal effective concentration: 238 nM
For compound 3 the middle estimate is 1.3-fold (0.13 log units) above the measured one, and the stated range covers the measured number.
By their numbers in this assay, from the lowest: compounds 1 and 3 (each within the scatter of the next); then compound 2.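

In this assay, placing 2-hydroxyethyl on the saturated chain carbon, two bonds along the chain from an aromatic carbon, gives a 1.3-fold higher number from compound 1 to compound 3 (0.11 log units; within the scatter). Within the data shown here, the earlier compounds offered no step that could be read at any single place, and this is the first to show that this carbon can carry the added chain, read one bond further out as methyl to 3-hydroxypropyl, with no difference beyond the scatter. No measured evidence bears on why the step is this size.

The compounds shown leave open what an amine or a carboxylic acid in place of the hydroxy group of this chain would give. They also leave open whether a longer chain at this carbon would still stay within the scatter of compound 1.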